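Hydroxy to bromo on the aromatic carbon

The source may report more compounds than this note shows. Statements on the series, on what has been measured and on what is new or still open speak of the compounds shown alone.

Three compounds of the shared core have been run in a functional assay, with a stated time of 30 min, tested at 20 uM; a lower number here means less inhibition, a higher number more inhibition at the concentration tested (going by the name of the read-out). Compound 1 `c1ccc(-c2nnc(Nc3ncccn3)o2)cc1` gives 51.4%. Compound 2 `COc1cc(-c2nnc(Nc3ncccn3)o2)cc(OC)c1OC` gives 57.7%. Compound 3 `Oc1ccc(-c2nnc(Nc3ncccn3)o2)cc1` gives 63.4%, the highest of the three numbers, though compound 2 lies within the scatter of it and only compound 1 is beyond it, the step being a number 12 percentage points higher from compound 1 to compound 3 (beyond the scatter). Compound 4 `Brc1ccc(-c2nnc(Nc3ncccn3)o2)cc1` differs from compound 3 by bromo in place of hydroxy on an aromatic carbon. Among the measured compounds shown here, no measured step bears on a bromo group; the only step that bears on this change is the modest one from hydrogen to hydroxy, so removing the hydroxy is expected to bring the number back toward that of compound 1, without a change beyond the scatter being assured. Compound 4 is therefore expected at 52%, with a range of 42% to 62%. This estimate amounts to a number 11.4 percentage points lower from compound 3 to compound 4 (beyond the scatter).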

Compound 4, a percentage reported as inhibition, at one concentration (the size of the read-out at that concentration, not a potency): 47.8%
For compound 4 the middle estimate is 4.2 percentage points above the measured one; the range from low to high includes it.
By their numbers in this assay, from the lowest: compounds 4, 1, 2 and 3 (each within the scatter of the next, the first and the last beyond it).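

At this aromatic carbon, para to a large group, bromo does not stand in for hydroxy in this assay: the change gives a number 15.6 percentage points lower from compound 3 to compound 4 (beyond the scatter) and so loses the gain seen with hydroxy. Bromo in place of hydrogen gives a number 3.6 percentage points lower from compound 1 to compound 4 (within the scatter) and leaves the number where hydrogen had it, so among these three groups only hydroxy stands apart at this position. Nothing measured bears on why hydroxy and bromo differ here.

As far as these compounds go, whether an amine or a carboxylic acid at this carbon would read with hydroxy or with bromo stays open. Also open, from the compounds shown here alone, is whether hydroxy keeps its gain on another carbon of the same ring.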